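Morpholin-4-yl in place of (3-nitrophenyl)amino in the series

The source may hold more compounds than are shown below. What is called first, only, known or untested is meant among the compounds shown, and "the series" means these compounds.

Measured so far:
compound 1 `CC1(C)N=C(N)N=C(N)N1c1cccc(CNC(=O)Nc2cccc(C#N)c2)c1` — 8.19
compound 2 `CC1(C)N=C(N)N=C(N)N1c1cccc(CNC(=O)Nc2cccc([N+](=O)[O-])c2)c1` — 8.1
compound 3 `CC1(C)N=C(N)N=C(N)N1c1ccc(CCC(=O)Nc2ccc(S(=O)(=O)F)cc2)c(Cl)c1` — 7.62

In an assay on isolated protein for inhibition of Dihydrofolate reductase (Mus musculus) (a higher number here means a more potent compound, by a factor of ten per unit of this negative logarithm, a lower number a less potent compound), compound 2 stands second highest of the three numbers; compound 1 sits a little higher, within the scatter, while compound 3 lies lower beyond it. Compound 4 `CC1(C)N=C(N)N=C(N)N1c1cccc(CNC(=O)N2CCOCC2)c1` differs from compound 2 by morpholin-4-yl in place of (3-nitrophenyl)amino on a carbonyl carbon. Among the measured compounds shown here, no measured step bears directly on this: the only one, a number 0.09 log units lower from compound 1 to compound 2 (within the scatter), swaps a substituent on the aromatic ring that is now removed. For the measured compounds named here, the change is therefore untested here, and because compound 3, the one measured compound without that ring, gives 7.62, a drop beyond the scatter is expected, a number 0.80 log units lower from compound 2 to compound 4 (beyond the scatter). Compound 4 is estimated at 7.3, range 6.5 to 8.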

Compound 4, logarithm of the reciprocal of the active concentration, log(1/C): 6.43
Estimate against measurement, compound 4: 0.87 log units above; the whole stated range lies above it.
By their numbers in this assay, from the lowest: compound 4; then compound 3; then compounds 2 and 1 (each within the scatter of the next).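

On the carbonyl carbon in this assay, morpholin-4-yl is a large loss against both aromatic amino groups: a number 1.67 log units lower from compound 2 to compound 4 (beyond the scatter), and a number 1.76 log units lower from compound 1 to compound 4 (beyond the scatter). This position therefore responds strongly to replacing the whole amino group, whereas exchanging nitro for cyano on the aromatic ring stayed within the scatter, a number 0.09 log units lower from compound 1 to compound 2 (within the scatter). Nothing available explains the loss.

The change removes both the aromatic ring and the amide hydrogen, so the compounds shown cannot separate the two. A cyclohexylamino group on the same carbonyl carbon would keep that hydrogen without the aromatic ring.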